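Quinolinone amides: lipophilicity notes, fluoro to chloro swap

A few compounds are considered here, and "the series" means these few. Any claim that something is new, unique, unknown or untested is made for them only; others in the source may bear on it.

Measured so far:
- compound 1, `Cc1cc(=O)[nH]c2cc(NC(=O)c3ccc(F)cc3)ccc12`: 1.61 in a physicochemical assay for lipophilicity; on this read-out higher numbers stand for higher lipophilicity and lower numbers for lower lipophilicity
- compound 2, `COc1ccc(C(=O)Nc2ccc3c(C)cc(=O)[nH]c3c2)cc1OC`: in this assay compound 2 gives 1.46
- compound 3, `Cc1cc(=O)[nH]c2cc(NC(=O)c3ccc(Cl)cc3Cl)ccc12`: in this assay compound 3 gives 1.83

All three share the same core and differ only in the aryl group on the amide carbonyl. On the numbers shown, compound 1 sits in the middle of the set: the value of compound 2 is the nearest and the value of compound 3 the furthest from it, yet both gaps fall within the usual scatter of this assay, so no order among the three can be read from these data.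

Compound 4, `Cc1cc(=O)[nH]c2cc(NC(=O)c3cccc(Cl)c3)ccc12`, has not been measured. Relative to compound 1 the change is 3-chlorophenyl in place of 4-fluorophenyl on a carbonyl carbon. Going by the values given here, no measured pair covers this exact swap, so the size of the step is not anchored by a measured difference. The expected step from compound 1 to compound 4 is estimated as a number 0.24 log units higher from compound 1 to compound 4 (within the scatter) in this assay, a modest move upward that may only just clear the scatter. On that basis compound 4 is expected to give about 1.85 in this assay, with a plausible range from 1.55 to 2.15.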

Compound 4, partition coefficient: 1.69
For compound 4 the middle estimate is 0.16 log units above the measured one; the measured number falls inside the stated range.
By their numbers in this assay, from the lowest: compounds 2, 1, 4 and 3 (each within the scatter of the next, the first and the last beyond it).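

In this assay, 3-chlorophenyl in place of 4-fluorophenyl on a carbonyl carbon gives a number 0.08 log units higher from compound 1 to compound 4 (within the scatter), so this read-out does not separate the two compounds. Going by these compounds alone, this is the first step that changes a single place, and it shows that this exchange of aryl groups on the shared core leaves compound 4 within the scatter of compound 1. No supporting data bear on the origin of this small step.

This single pair changes both the halogen and its place on the ring, so it cannot show which of the two matters here, if either does. Also open, on these data alone, is whether a non-aryl group on the same carbonyl carbon, such as an amine or a longer chain carrying a carboxylic acid, would give a step beyond the scatter in this assay.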